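This account rests on a few compounds, and the source may have more. Where it says the series, first, only, none or still open, it means among the compounds named here.

Three compounds have been measured in a functional assay on PC-3 cells (Homo sapiens) for cytotoxicity, read by MTT assay, with a stated time of 72 h; a higher number here means a weaker inhibitor, a lower number a stronger inhibitor:

Compound 1 `O=C(Nc1ccc(Oc2ccnc3[nH]ccc23)cc1)c1nn(-c2ccc(Cl)c(C(F)(F)F)c2)ccc1=O`: 4630 nM
Compound 2 `O=C(Nc1ccc(Oc2ccnc3[nH]ccc23)c(F)c1)c1nn(-c2ccc(Br)cc2)ccc1=O`: 40800 nM
Compound 3 `O=C(Nc1ccc(Oc2ccnc3[nH]ccc23)c(F)c1)c1nn(-c2ccc(Cl)c(F)c2)ccc1=O`: 13600 nM

Compound 3 holds the second highest of the three numbers: compound 1 sits nearest, with a lower number, and compound 2 furthest, with a higher one. For the measured compounds named here, the only step with a single change is a 3.0-fold lower number from compound 2 to compound 3 (0.48 log units; beyond the scatter), which alters the aryl group on the aromatic nitrogen and shows that this part of the molecule moves the number by a modest amount.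

Compound 4 `O=C(Nc1ccc(Oc2ccnc3[nH]ccc23)c(F)c1)c1nn(-c2ccc(Cl)c(C(F)(F)F)c2)ccc1=O` arises from compound 3 by trifluoromethyl in place of fluoro on an aromatic carbon. Going by the values given here, no measured pair isolates this swap. Among the compounds with values here, compound 1 carries the same 4-chloro-3-(trifluoromethyl)phenyl group but lacks the fluoro on the core, so its value and that of compound 3 combine two differences and show only that the pair with the trifluoromethyl group gave the lower number.

Given that, compound 4 is expected to land somewhat lower than compound 3, a step of about a 2.1-fold lower number from compound 3 to compound 4 (0.32 log units; beyond the scatter). The estimate for compound 4 in this assay is 6500 nM, within a range of 2500 nM to 16000 nM.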

Compound 4, half-maximal inhibitory concentration: 5500 nM
The estimate for compound 4 lay 1.2-fold (0.07 log units) above the measured number; low and high end bracket the measured number.
By their numbers in this assay, from the lowest: compounds 1 and 4 (each within the scatter of the next); then compound 3; then compound 2.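

In this assay, the change from fluoro to trifluoromethyl on the aromatic carbon ortho to a chloro group now stands alone on one core, and it gives a 2.5-fold lower number from compound 3 to compound 4 (0.39 log units; beyond the scatter). On the aromatic nitrogen, the 4-chloro-3-(trifluoromethyl)phenyl group in place of 4-bromophenyl gives a 7.4-fold lower number from compound 2 to compound 4 (0.87 log units; beyond the scatter), the largest single-place step shown so far. For the compounds shown here, the fluoro on the shared core, read alone for the first time, gives a 1.2-fold higher number from compound 1 to compound 4 (0.07 log units; within the scatter), so the two compounds cannot be told apart here, and no measurement at hand explains any of these steps.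

On these data alone, whether a nitrile or a methoxy group at this position would move the number in the same way stays open. So does what happens when the chloro group gives way to hydrogen.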